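Aryl ether variation at the chain terminus

The compounds below may be only part of what the source reports. "The series", "measured", "known", "first", "only" and "open" are said of these compounds alone.

Compound 1 `CC(C)CC(=O)c1ccc(OCCCCOc2ccccc2)c(Br)c1O` gives 1500 nM in a functional assay for binding affinity to metabotropic glutamate receptor 2 (Homo sapiens), read by GTPgammaS binding; on this read-out lower numbers stand for an effect already at smaller amounts and higher numbers for an effect only at larger amounts of compound; compound 2 `CC(C)CC(=O)c1ccc(OCCCCOc2cccc(F)c2F)c(Br)c1O` gives 558 nM in this assay, the lower of the two numbers, with a 2.7-fold lower number from compound 1 to compound 2 (0.43 log units; beyond the scatter). Compound 3 `CC(C)CC(=O)c1ccc(OCCCCOc2cccnc2)c(Br)c1O` differs from compound 2 by pyridin-3-yl in place of 2,3-difluorophenyl on an oxygen on a saturated carbon. Within the data shown here, no measured step exchanges the carbon-only ring for a ring with a hetero atom; the single step, from phenyl to 2,3-difluorophenyl, is the only guide, and the change toward pyridin-3-yl is of another kind. The expected step for compound 3 is a 2.2-fold higher number from compound 2 to compound 3 (0.33 log units; beyond the scatter), back toward the value of compound 1, 1500 nM. The estimate for compound 3 is 1200 nM, between 400 nM and 3500 nM.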

Compound 3, half-maximal effective concentration: 575 nM
Compound 3: the middle estimate sits 2.1-fold (0.32 log units) above what was measured; the range from low to high includes it.
By their numbers in this assay, from the lowest: compounds 2 and 3 (each within the scatter of the next); then compound 1.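

Pyridin-3-yl in place of 2,3-difluorophenyl gives a 1.0-fold higher number from compound 2 to compound 3 (0.01 log units; within the scatter) in this assay so at this place a ring with one hetero atom and no fluorine stands level with the difluorinated carbon ring. Against the plain phenyl ring, the same exchange gives a 2.6-fold lower number from compound 1 to compound 3 (0.42 log units; beyond the scatter) so fluorine is not required for the lower number. No data on hand explain this match.

Still open, as far as these compounds go, is whether pyridin-4-yl or pyrimidin-5-yl would hold this level, and whether the ring's nitrogen itself matters.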